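This account rests on a few compounds, and the source may have more. Where it says the series, first, only, none or still open, it means among the compounds named here.

Compound 2, `Cc1ccc([C@@H](C)Oc2cc3oc(=O)n(CCC(=O)O)c3cc2Cl)nc1`, gives 3.16 nM in an assay for inhibition of kynurenine 3-monooxygenase (Homo sapiens), read by mass spectrometry, with a stated time of 1 h; on this read-out lower numbers stand for stronger inhibition and higher numbers for weaker inhibition. Among the compounds with values here, the one neighbour measured so far, compound 1, `C[C@@H](Oc1cc2oc(=O)n(CCC(=O)O)c2cc1Cl)c1ccc(Cl)cn1`, gives 3.16 nM in this assay, so compound 2 stands level with it, the step being no change at the digits printed from compound 1 to compound 2 (within the scatter). Compound 3, `Cc1cccc([C@@H](C)Oc2cc3oc(=O)n(CCC(=O)O)c3cc2Cl)n1`, has not yet been measured; it differs from compound 2 in this way: 6-methylpyridin-2-yl in place of 5-methylpyridin-2-yl on a saturated chain carbon bound to an oxygen on an aromatic ring and a saturated chain carbon. Within the data shown here, no measured step concerns the pyridine ring or the methyl on it; the only step available, no change at the digits printed from compound 1 to compound 2 (within the scatter), changes a group on the shared core and was flat, which tells little about a rearranged 6-methylpyridin-2-yl. The account therefore expects compound 3 to sit close to compound 2 in this assay, with the step of a 1.4-fold higher number from compound 2 to compound 3 (0.15 log units; within the scatter) expected to fall within the scatter. The estimate for compound 3 in this assay is 4.5 nM, with a range from 1.5 nM to 15 nM.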

Compound 3, half-maximal inhibitory concentration in the kynurenine 3-monooxygenase assay: 5.01 nM
For compound 3 the middle estimate is 1.1-fold (0.05 log units) below the measured one; low and high end bracket the measured number.
By their numbers in the kynurenine 3-monooxygenase assay, from the lowest: compounds 1, 2 and 3 (each within the scatter of the next).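

Within the data shown here, in the kynurenine 3-monooxygenase assay, this is the first change to the arrangement of the pyridine ring on the saturated chain carbon, and 6-methylpyridin-2-yl in place of 5-methylpyridin-2-yl stays within the scatter (a 1.6-fold higher number from compound 2 to compound 3 (0.20 log units; within the scatter)), as does 6-methylpyridin-2-yl in place of 5-chloropyridin-2-yl (a 1.6-fold higher number from compound 1 to compound 3 (0.20 log units; within the scatter)). In a physicochemical assay for lipophilicity, read by HPLC, at pH 7.4 (a higher number here means a more lipophilic compound, a lower number a more polar compound), compound 2 gives 2.02 and compound 3 gives 2.12, so the same change also stays within the scatter on this read-out (a number 0.10 log units higher from compound 2 to compound 3 (within the scatter)). Nothing available explains why these pyridine groups read alike.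

The compounds shown leave open whether a methoxy, a trifluoromethyl or an amine on the pyridine ring would keep the number in this range. They also leave open whether a phenyl ring in place of the pyridine would do so.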